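The source may report more compounds than this note shows. Statements on the series, on what has been measured and on what is new or still open speak of the compounds shown alone.

Working notes on the series. In an assay on cells for inhibition of HSP60/HSP10 (Homo sapiens), with a stated time of 60 min (on this read-out lower numbers stand for stronger inhibition and higher numbers for weaker inhibition), compound 1 `O=S(=O)(Nc1ccc(-c2nc3ccccc3o2)cc1)c1ccc(Cl)c(C(F)(F)F)c1` gives 12000 nM, and compound 3 `CS(=O)(=O)Nc1ccc(-c2nc3cc(NS(=O)(=O)c4ccc(Cl)s4)ccc3o2)cc1` gives 43000 nM; the two differ in several places at once, so their values are simply set side by side. Compound 2 `Cc1ccc(S(=O)(=O)Nc2ccc3oc(-c4ccccc4)nc3c2)cc1` gives only a limit in this assay, > 100000 nM, which is not a number. That limit is the limit of > 100000 nM in this assay, at which 1 of the 3 values shown sits. Compound 2 thus stands with no value of its own, only the boundary of what the assay can report.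

Compound 4 `COc1ccccc1S(=O)(=O)Nc1ccc2oc(-c3ccccc3)nc2c1` has not been measured. It differs from compound 2 by 2-methoxyphenyl in place of 4-methylphenyl on a sulfonyl sulfur. Within the data shown here, no step between two measured compounds touches this part of the molecule, so the data give no ground for a step of any size in either direction. The expectation for compound 4 in this assay is therefore a step of a number no higher from compound 2 to compound 4 (the limit leaves the size open) of nothing beyond the scatter, with a second limit the likelier outcome. Compound 4 is estimated at 100000 nM, within 30000 nM to 300000 nM.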

Compound 4, half-maximal inhibitory concentration: > 100000 nM
Compound 4 gave a limit, no number; the forecaster's own chance of this, stated with the estimate: 65%; the middle value sits exactly at the limit.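

Compound 2 and compound 4 each give only a limit in this assay, not a number, so no step can be read between them: the limit of > 100000 nM in this assay, at which 2 of the 4 values shown sit.

The compounds shown leave open whether 2-methoxyphenyl in place of 4-methylphenyl on a sulfonyl sulfur changes inhibition at all.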